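Halogen on the core ring: bromo analogue of compound 2

The source may hold more compounds than are shown below. What is called first, only, known or untested is meant among the compounds shown, and "the series" means these compounds.

Measured so far:
compound 1 `O=C(CCCc1ccccc1)Nc1nc2cc(Cl)ccc2c(=O)s1` gives 1220 nM in an assay on mitochondria (strain Sprague-Dawley) for inhibition of Amine oxidase [flavin-containing] B (Rattus norvegicus), read by fluorescence and Amplex Red, with stated times of 30 min and 45 min; on this read-out higher numbers stand for weaker inhibition and lower numbers for stronger inhibition
compound 2 `O=C(CCCc1ccccc1)Nc1nc2ccccc2c(=O)s1` gives 186 nM in this assay
compound 3 `COc1cccc(CCC(=O)Nc2nc3ccccc3c(=O)s2)c1` gives 621 nM in this assay

Compound 2 stands at the lowest number of the three; compound 3 is nearest, at a 3.3-fold higher number from compound 2 to compound 3 (0.52 log units; beyond the scatter), and compound 1 is furthest, at a 6.6-fold lower number from compound 1 to compound 2 (0.82 log units; beyond the scatter) read the other way.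

The next compound, compound 4 `O=C(CCCc1ccccc1)Nc1nc2ccc(Br)cc2c(=O)s1`, keeps the chain of compound 2 and changes only the core ring: bromo in place of hydrogen on an aromatic carbon.

Within the data shown here, only one measured step speaks to a halogen on this ring: a 6.6-fold lower number from compound 1 to compound 2 (0.82 log units; beyond the scatter), where the chloro leaves and the number falls by a modest but real amount. Among the measured compounds shown here, compound 4 is not a plain exchange of that chloro for bromo, and no step with bromo exists in the set, so the transfer is uncertain. The step of a 3.3-fold higher number from compound 2 to compound 3 (0.52 log units; beyond the scatter) concerns the chain and bears only loosely on it.

For the measured compounds named here, on the one halogen step available, a rise in this assay is expected from compound 2 to compound 4, of about a 3.5-fold higher number from compound 2 to compound 4 (0.54 log units; beyond the scatter), with a wide range.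

Compound 4 is therefore estimated at 650 nM in this assay, expected to fall between 250 nM and 1800 nM.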

Compound 4, half-maximal inhibitory concentration: > 10000 nM
Compound 4 gave a limit, no number (the forecaster's own chance of this, stated with the estimate: 3%); middle value at least 15-fold (1.18 log units) from the limit.
By their numbers in this assay, from the lowest: compound 2; then compounds 3 and 1 (each within the scatter of the next). At a limit, above all of these: compound 4.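

Compound 4 gives no number in this assay, only a limit: the limit of > 10000 nM in this assay, at which 1 of the 4 values shown sits. With bromo in place of hydrogen on this aromatic carbon, meta to a fused ring and para to a fused ring, the series shows an at least 53-fold higher number from compound 2 to compound 4 (1.73 log units; beyond the scatter), a large step that leaves the chain of compound 2 untouched, so a single heavy atom on the core ring is enough to take inhibition out of the measurable range of this assay. Among these compounds, the only earlier halogen step, a 6.6-fold lower number from compound 1 to compound 2 (0.82 log units; beyond the scatter), is modest and involves chloro on a different carbon, so the earlier compounds gave no sign that a halogen on the core ring could cost this much.

The compounds shown do not separate the effect of the bromo group itself from that of the carbon it occupies, since bromo on the carbon that carries chloro in compound 1 and chloro on the carbon that carries bromo in compound 4 are both absent from this set. As far as these compounds go, whether a fluoro, a methyl or a methoxy on this same carbon would keep any inhibition also stays open.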